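Formyl on the Fused Core: Expected Paw Edema Inhibition

This account rests on a few compounds, and the source may have more. Where it says the series, first, only, none or still open, it means among the compounds named here.

Measured so far:
compound 1 `Cc1ccc2c(Cc3nn4cc(-c5ccc(Br)cc5)nc4s3)coc2c1`: 10.3%
compound 2 `Cc1ccc2c(Cc3nn4cc(-c5ccc([N+](=O)[O-])cc5)nc4s3)coc2c1`: 13.4%

In a functional assay on the whole organism (strain Wistar albino) for inhibition, with Rattus norvegicus as the target, read by paw edema, with a stated time of 1 h, at a dose of 100 mg/kg by the oral route (a higher number here means more inhibition at the dose given (going by the name of the read-out), a lower number less inhibition), compound 1 gives 10.3%, the lowest of the two numbers measured, while compound 2 gives 13.4%. For the measured compounds named here, the only measured step, a number 3.1 percentage points higher from compound 1 to compound 2 (within the scatter), lies within the scatter and concerns the 4-bromophenyl group rather than the fused core.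

Compound 3 `Cc1ccc2c(Cc3nn4c(C=O)c(-c5ccc(Br)cc5)nc4s3)coc2c1` differs from compound 1 by formyl in place of hydrogen on an aromatic carbon. Going by the values given here, no measured step touches this place on the core, so the one measured step offers no direct guidance, and the only thing the data show is that both measured compounds give low inhibition in this assay that cannot be told apart.

The step from compound 1 to compound 3 is therefore expected to be a number 1.7 percentage points higher from compound 1 to compound 3 (within the scatter), not beyond the scatter in either direction. Compound 3 is estimated at 12%, in the range 2% to 24%.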

Compound 3, a percentage reported as inhibition, in the whole organism at one dose (the size of the read-out at that dose, not a potency): 12.4%
Compound 3: the middle estimate sits 0.4 percentage points below what was measured; measured number inside the range.
By their numbers in this assay, from the lowest: compounds 1, 3 and 2 (each within the scatter of the next).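

Formyl in place of hydrogen, on an aromatic carbon of the five-membered aromatic ring with 2 nitrogen, gives a number 2.1 percentage points higher from compound 1 to compound 3 (within the scatter) in this assay. For the compounds shown here, this is the first reading for a change at this place on the shared core, and it shows that adding formyl here brings no difference from hydrogen that can be told from the usual scatter at this single dose and time. No measurement at hand bears on this result or offers an explanation for it.

The compounds shown leave open what an amine, a carboxylic acid or a longer chain at this same place would do to the inhibition of paw edema. They also leave open whether formyl would read the same on the core of compound 2, which carries nitro in place of bromo.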